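Five-membered ring swap from compound 3 to compound 4

This account rests on a few compounds, and the source may have more. Where it says the series, first, only, none or still open, it means among the compounds named here.

Compound 1 `Cc1nc(-c2ccccc2NCC2=NCCN2)cs1` gives in a functional assay for activation of Alpha-1D adrenergic receptor (Homo sapiens) (a lower number here means that less compound is needed, a higher number that more compound is needed for the effect), a limit, < 5020 nM.
Compound 2 `Cc1nc(-c2ccccc2NCC2=NCCN2)co1` gives in this assay a limit, < 5020 nM.
Compound 3 `Cc1cc(-c2ccccc2NCC2=NCCN2)on1` gives in this assay a limit, < 100000 nM.

Compound 3 stands only as a limit, and the two other values are limits as well, at the limit of < 5020 nM in this assay, at which 2 of the 3 values shown sit. The steps a step that the two limits leave unreadable from compound 1 to compound 2, a step that the two limits leave unreadable from compound 1 to compound 3 and a step that the two limits leave unreadable from compound 2 to compound 3 therefore give no readable size. Compound 4 `Cc1noc(-c2ccccc2NCC2=NCCN2)n1` carries the change (3-methyl-1,2,4-oxadiazol-5-yl in place of 3-methyl-1,2-oxazol-5-yl on an aromatic carbon). Going by the values given here, no measured step bears readably on it, so the expected step that the limit leaves unreadable from compound 3 to compound 4 is an open guess, with a fair chance that this assay again returns only a limit. For compound 4 the estimate is 10000 nM, in the range 500 nM to 100000 nM.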

Compound 4, half-maximal effective concentration: < 5020 nM
Compound 4: no number, only a limit (the forecaster's own chance of this, stated with the estimate: 60%); middle value at least 1.9-fold (0.29 log units) from the limit.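

Going by these compounds alone, compound 4 gives in this assay only a limit, < 5020 nM, so no step from compound 1, compound 2 or compound 3 to compound 4 can be read. The compounds shown leave open whether any of these five-membered ring swaps changes the response in this assay, and by how much.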